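From Difluorophenyl to Acetylphenyl: Expected Cytotoxicity

The compounds below may be only part of what the source reports. "The series", "measured", "known", "first", "only" and "open" are said of these compounds alone.

Compound 1 `Cc1ccc(NC(=O)C(=O)NC(c2nc(C)c(CO)s2)C2CCCCN2)c(F)c1`: in an ADME assay on TZM-b1 cells (Homo sapiens) for cytotoxicity, read by XTT assay, with a stated time of 3 days (on this read-out higher numbers stand for lower toxicity in this test and lower numbers for higher toxicity in this test), compound 1 gives > 88000 nM, which is a limit of the assay and not a number.
Compound 2 `Cc1nc(C(NC(=O)C(=O)Nc2ccc(F)c(F)c2)C2CCCCN2)sc1CO`: in this assay compound 2 gives > 87000 nM, again a limit of the assay.

Compound 2 therefore stands at the top of what this assay can report, as does compound 1, so the step that the two limits leave unreadable from compound 1 to compound 2 cannot be read; the two reported limits are the limit of > 87000 nM in this assay, at which 1 of the 2 values shown sits, and (the limit of > 88000 nM in this assay, at which 1 of the 2 values shown sits). Compound 3 `CC(=O)c1ccc(NC(=O)C(=O)NC(c2nc(C)c(CO)s2)C2CCCCN2)cc1` is not yet measured. It differs from compound 2 in one place: 4-acetylphenyl in place of 3,4-difluorophenyl on an amide-type nitrogen. Going by the values given here, the only measured step that bears on this position was unreadable, and it gives no sign of a change beyond the scatter. The expectation for compound 3 in this assay is therefore another reading at or near the limit, estimated at 90000 nM (range 35000 nM to 250000 nM). The step that this estimate means, from compound 2 to compound 3, is expected to be a step that the limit leaves unreadable from compound 2 to compound 3.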

Compound 3, half-maximal cytotoxic concentration: > 86000 nM
Compound 3 gave a limit, no number; the forecaster's own chance of this, stated with the estimate: 75%; the middle value lies beyond the limit too.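

Compound 3 gives only a limit of the assay in this assay, as do compound 1 and compound 2, and no step among these three compounds can be read. The compounds shown leave open at what concentration, if any, each would become toxic to these cells.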